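The source may report more compounds than this note shows. Statements on the series, on what has been measured and on what is new or still open speak of the compounds shown alone.

Compounds measured in a functional assay on HeLa cells (Homo sapiens) for antiproliferative activity, read by MTT assay, with a stated time of 72 h; a higher number here means a weaker inhibitor, a lower number a stronger inhibitor:
compound 1, `O=C1O/C(=C\Cn2cc(-c3ccc(Br)cc3)nn2)C(OCc2ccccc2)=C1OCc1ccccc1`, 24300 nM
compound 2, `O=C1O[C@H]([C@@H](O)Cn2cc(CNS(=O)(=O)c3ccc(F)cc3)nn2)C(OCc2ccccc2)=C1OCc1ccccc1`, 25000 nM
compound 3, `CC(C)(C)c1cn(C[C@H](O)[C@H]2OC(=O)C(OCc3ccccc3)=C2OCc2ccccc2)nn1`, 18300 nM

On the numbers shown, compound 1 sits with compound 2 and compound 3 in one narrow band; none of the three is separated from another by more than the scatter, so no order among them can be read.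

Compound 4, `COc1ccccc1-c1cn(C/C=C2\OC(=O)C(OCc3ccccc3)=C2OCc2ccccc2)nn1`, keeps the core of compound 1 and differs in one place: 2-methoxyphenyl in place of 4-bromophenyl on an aromatic carbon.

Among the measured compounds shown here, only one measured step touches the same position, the swap on the five-membered ring between compound 2 and compound 3, where a 1.4-fold lower number from compound 2 to compound 3 (0.14 log units; within the scatter). That step sits in the hydroxy-bearing series rather than in the exocyclic-alkene series of compound 1 and compound 4, and it exchanges a sulfonamide-bearing chain for tert-butyl rather than one aryl group for another, so it bears on the present change only loosely. For the measured compounds named here, no step in the set exchanges one aryl group for another on this ring carbon. With nothing to suggest movement, the step from compound 1 to compound 4 is expected to stay within the scatter, a 1.1-fold lower number from compound 1 to compound 4 (0.04 log units; within the scatter).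

Compound 4 is therefore estimated at 22000 nM in this assay, within a range of 8000 nM to 60000 nM.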

Compound 4, half-maximal inhibitory concentration: > 100000 nM
Compound 4 was reported as a limit; the forecaster's own chance of this, stated with the estimate: 10%; at least 4.5-fold (0.65 log units) between middle value and limit.
By their numbers in this assay, from the lowest: compounds 3, 1 and 2 (each within the scatter of the next). At a limit, above all of these: compound 4.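

In this assay, the aromatic carbon of the five-membered ring is a position where the group matters: on the shared core, 2-methoxyphenyl in place of 4-bromophenyl gives an at least 4.1-fold higher number from compound 1 to compound 4 (0.61 log units; beyond the scatter). Among the compounds shown here, compound 4 stands as a limit and not as a number in this assay: the limit of > 100000 nM in this assay, at which 1 of the 4 values shown sits. The earlier compounds showed no movement on this ring carbon, since even the exchange of the (((4-fluorophenyl)sulfonyl)amino)methyl group for tert-butyl gave a 1.4-fold lower number from compound 2 to compound 3 (0.14 log units; within the scatter), whereas here a change from one aryl group to another carries the number beyond the scatter.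

The compounds shown cannot separate the loss of 4-bromophenyl from the arrival of 2-methoxyphenyl, and plain phenyl, 4-methoxyphenyl or 2-bromophenyl on the same carbon would be needed to tell these apart. Going by these compounds, it also remains open whether the same aryl exchange has a similar effect in the hydroxy-bearing series of compound 2 and compound 3, and whether an aryl group carrying an amine or a carboxylic acid would stay in the band of compound 1.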